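The source may hold more compounds than are shown below. What is called first, only, known or untested is meant among the compounds shown, and "the series" means these compounds.

Two compounds share one core and differ only in the group on a saturated chain carbon bound to an oxygen on an aromatic ring. Compound 1 `C=CCOn1c(-c2cccc(C#N)c2)nc(C)c1C(=O)OCC` carries a vinyl there; in a functional assay on a cell-free system (plasma, Oryctolagus cuniculus) for inhibition, with stated times of 5 min, 1 min and 6 min (on this read-out higher numbers stand for weaker inhibition and lower numbers for stronger inhibition), compound 1 gives 5860 nM. Compound 2 `CCOC(=O)c1c(C)nc(-c2cccc(C#N)c2)n1OCc1ccccc1Cl` carries a 2-chlorophenyl instead, and in this assay compound 2 gives 8710 nM. Within the data shown here, that single change gave a 1.5-fold higher number from compound 1 to compound 2 (0.17 log units; within the scatter), so compound 2 stands at the higher of the two numbers measured so far, but the gap to compound 1 lies within the scatter. Compound 3 `CCOC(=O)c1c(C)nc(-c2cccc(C#N)c2)n1OCc1cccc(C#N)c1` is not yet measured; it differs from compound 2 by 3-cyanophenyl in place of 2-chlorophenyl on a saturated chain carbon bound to an oxygen on an aromatic ring. Among the measured compounds shown here, the only measured step at this place, from vinyl to 2-chlorophenyl, stayed within the scatter, so the swap of 2-chlorophenyl for 3-cyanophenyl is expected to stay within the scatter as well, as a 1.0-fold lower number from compound 2 to compound 3 (0.01 log units; within the scatter). Compound 3 is therefore estimated at 8500 nM, between 4000 nM and 18000 nM.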

Compound 3, half-maximal inhibitory concentration: > 30000 nM
Compound 3 was reported as a limit; the forecaster's own chance of this, stated with the estimate: 5%; middle value at least 3.5-fold (0.54 log units) away from the limit.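

In this assay compound 3 is recorded only as a limit of the assay, not as a number: the limit of > 30000 nM in this assay, at which 1 of the 3 values shown sits.

Even so, this position is not indifferent to what it carries: the swap to 3-cyanophenyl gives an at least 3.4-fold higher number from compound 2 to compound 3 (0.53 log units; beyond the scatter), and measured against vinyl the same group gives an at least 5.1-fold higher number from compound 1 to compound 3 (0.70 log units; beyond the scatter). The earlier step from vinyl to 2-chlorophenyl stayed within the scatter and suggested a tolerant place, whereas this result shows that a substituted phenyl here can clearly weaken inhibition, so a large group alone does not settle the outcome.

On these data alone, the true number of compound 3 remains open, as does whether the loss follows the nitrile or where it stands on the ring, since the swap changes both. Also open, as far as these compounds go, is how a plain benzyl, or a benzyl bearing an amine or a carboxylic acid, would behave here.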